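From Bromophenyl to Trifluorophenyl on a Shared Core

The source may hold more compounds than are shown below. What is called first, only, known or untested is meant among the compounds shown, and "the series" means these compounds.

Compound 1 `OC[C@H]1O[C@@H](n2cnc3c(NCc4ccc(Br)cc4)ncnc32)[C@H](O)[C@@H]1O` is the measured starting point in a functional assay on HOS cells (Homo sapiens) for antiproliferative activity, with a stated time of 72 h; a higher number here means a weaker inhibitor, a lower number a stronger inhibitor. In this assay compound 1 gives > 166000 nM, which is a limit of the assay and not a measured number. Among the two readings given, compound 1 therefore sits at the limit of > 166000 nM in this assay, at which 1 of the 2 values shown sits. Compound 2 `OC[C@H]1O[C@@H](n2cnc3c(NCc4cc(F)cc(F)c4)ncnc32)C(O)C1O` shares the core but carries a different substituent; in this assay compound 2 is recorded as "not determined" (no result reported), so it contributes no number. Compound 3 `OC[C@H]1O[C@@H](n2cnc3c(NCc4ccc(F)c(F)c4F)ncnc32)[C@H](O)[C@@H]1O` is the unmeasured partner of compound 1. The change is 2,3,4-trifluorophenyl in place of 4-bromophenyl on a saturated chain carbon bound to a nitrogen on an aromatic ring. Among the measured compounds shown here, no measured step between two numbered compounds exists here, so the expectation rests on compound 1, which in this assay gives > 166000 nM. Compound 3 is expected to show a step that the limit leaves unreadable from compound 1 to compound 3, that is, none beyond the scatter. Compound 3 is estimated at 200000 nM, with a range from 50000 nM to 800000 nM, and very likely only a limit is reported again.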

Compound 3, half-maximal inhibitory concentration: > 166000 nM
Compound 3: only a limit was reported; the forecaster's own chance of this, stated with the estimate: 80%; the middle value is on the limit's open side.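

Compound 1 and compound 3 each give only a limit of the assay and not a number, so no step between them can be read: the limit of > 166000 nM in this assay, at which 2 of the 3 values shown sit.

The compounds shown leave open whether 2,3,4-trifluorophenyl in place of 4-bromophenyl changes the activity of the shared core in this assay.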